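The source may hold more compounds than are shown below. What is called first, only, known or untested is meant among the compounds shown, and "the series" means these compounds.

Three compounds have been measured so far in a functional assay on DU-145 cells (Homo sapiens) for cytotoxicity, read by MTT assay, with a stated time of 48 h; a higher number here means a weaker inhibitor, a lower number a stronger inhibitor

Compound 1 `O=C1Nc2ccccc2C1(c1c[nH]c2ccccc12)c1c[nH]c2ccccc12` gives 8700 nM
Compound 2 `COc1ccc2c(C3(c4c[nH]c5cc(OC)ccc45)C(=O)Nc4ccccc43)c[nH]c2c1` gives 1200 nM
Compound 3 `O=C1Nc2ccccc2C1(c1c[nH]c2ccc(Cl)cc12)c1c[nH]c2ccc(Cl)cc12` gives 8100 nM

Compound 1 stands at the weak end of this small set, within the scatter of compound 3, while compound 2 shows a clearly lower number. Compound 4 `O=C1Nc2ccc(F)cc2C1(c1c[nH]c2ccccc12)c1c[nH]c2ccccc12` keeps the core of compound 1 and brings one change (fluoro in place of hydrogen on an aromatic carbon), fluoro in place of hydrogen on an aromatic carbon. Within the data shown here, no two measured compounds differ in one place only, so the data give no direct measure of such a change. No step beyond the scatter is therefore expected in this assay, at most a slight shift toward a lower number. This expectation leans on compound 3, a halogen-bearing compound, whose 8100 nM stays within the scatter of compound 1. The estimated step is small (a 1.5-fold lower number from compound 1 to compound 4 (0.16 log units; within the scatter)) and is expected to stay within the scatter. For compound 4 the expected value is 6000 nM, with an estimated range from 2500 nM to 14000 nM.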

Compound 4, half-maximal inhibitory concentration: 12800 nM
The estimate for compound 4 lay 2.1-fold (0.33 log units) below the measured number, within the range that was stated.
By their numbers in this assay, from the lowest: compound 2; then compounds 3, 1 and 4 (each within the scatter of the next).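

In this assay, fluoro in place of hydrogen on an aromatic carbon of the core of compound 1 gives a 1.5-fold higher number from compound 1 to compound 4 (0.17 log units; within the scatter), the first direct measure of a single change in this set. At this position, a carbon of a six-membered aromatic ring of carbon only, part of a fused system of two rings, the fluoro group therefore leaves the reading within the scatter, so this position tolerates the exchange without a measurable gain or loss in this assay. No measured property is available that would account for this outcome.

As far as these compounds go, whether a group of another kind at the same position, such as an amine or a carboxylic acid, would take the number beyond the scatter remains open. The same holds for a longer chain there, since one small atom says little about the position as a whole.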